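The source may hold more compounds than are shown below. What is called first, only, known or untested is meant among the compounds shown, and "the series" means these compounds.

Measured in an assay on isolated protein for binding affinity to Adrenergic receptor alpha-1 (Rattus norvegicus); a lower number here means a stronger inhibitor, a higher number a weaker inhibitor:
compound 1 `COc1cccc(N2CCN(CCCCN3C(=O)CC(C)(C)CC3=O)CC2)n1`, 68 nM
compound 2 `N#Cc1cccnc1N1CCN(CCCCN2C(=O)CSC2=O)CC1`, 39 nM
compound 3 `COC(=O)c1cccnc1N1CCN(CCCCN2C(=O)SC3(CCCC3)C2=O)CC1`, 7.8 nM

Compound 3 has the lowest number of the three. Its gap to compound 2 and to compound 1 each lies beyond the usual scatter, compound 1 being the furthest away.

Compound 4 `O=C1SC2(CCCC2)C(=O)N1CCCCN1CCN(c2ncccc2Cl)CC1` is not yet measured in this assay. It differs from compound 3 in one place: chloro in place of methoxycarbonyl on an aromatic carbon. For the measured compounds named here, no measured pair shows this change, so its size is unknown; compound 2, which carries a nitrile and a differing core, gives 39 nM and offers no direct guide.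

Expected for compound 4: a modest rise in number, the step of a 1.9-fold higher number from compound 3 to compound 4 (0.28 log units; within the scatter). The estimate for compound 4 is 15 nM, with a range of 4 nM to 60 nM.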

Compound 4, half-maximal inhibitory concentration: 19.9 nM
The estimate for compound 4 lay 1.3-fold (0.12 log units) below the measured number; the range from low to high includes it.
By their numbers in this assay, from the lowest: compound 3; then compounds 4, 2 and 1 (each within the scatter of the next, the first and the last beyond it).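

First matched pair in the series: in this assay, chloro in place of methoxycarbonyl on the aromatic carbon ortho to a large group gives a 2.6-fold higher number from compound 3 to compound 4 (0.41 log units; beyond the scatter), a modest step but beyond the scatter. This position therefore responds to the group it carries, and a single chlorine keeps most of the affinity of the four-heavy-atom ester. Nothing available accounts for the step.

Left open: how a fluoro, an amine or a carboxylic acid at this position would read, and whether the same change gives a similar step on the cores of compound 1 and compound 2.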